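The compounds below may be only part of what the source reports. "The series", "measured", "known", "first", "only" and "open" are said of these compounds alone.

Three compounds of the series have numbers in a functional assay on MDA-MB-231 cells (Homo sapiens) for antiproliferative activity, read by CCK-8 assay, with a stated time of 72 h; on this read-out higher numbers stand for weaker inhibition and lower numbers for stronger inhibition. Compound 1 `CC1=NN(c2cccc(Cl)c2)C(=O)C12C=CC(=O)C=C2c1cccc(C)c1` gives 22300 nM. Compound 2 `CC1=NN(c2ccc(Cl)cc2)C(=O)C12C=CC(=O)C=C2c1cccc(C)c1` gives 26900 nM. Compound 3 `CC1=NN(c2ccc(Br)cc2)C(=O)C12C=CC(=O)C=C2c1ccc(C)cc1` gives 15900 nM, the lowest of the three numbers, though its gaps to compound 1 and to compound 2 both lie within the scatter, so no ordering among the three can be drawn. Going by the values given here, the only single-point step measured so far is a 1.2-fold higher number from compound 1 to compound 2 (0.08 log units; within the scatter), which exchanges one chlorophenyl isomer for another on the ring nitrogen and does not move the number beyond the scatter.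

Compound 4 `CC1=NN(c2ccc(Br)cc2)C(=O)C12C=CC(=O)C=C2c1cccc(C)c1` is not yet measured. It differs from compound 3 in one place: 3-methylphenyl in place of 4-methylphenyl on a double-bonded ring carbon. Among the compounds with values here, the closest precedent is the chlorophenyl exchange above, which is an isomer swap of the same kind and stayed within the scatter; nothing else bears on this change. The expectation for compound 4 in this assay is therefore a number within the scatter of compound 3, that is a 1.1-fold higher number from compound 3 to compound 4 (0.03 log units; within the scatter) expected. Compound 4 is estimated at 17000 nM, with a range from 8000 nM to 36000 nM.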

Compound 4, half-maximal inhibitory concentration: 2890 nM
For compound 4 the middle estimate is 5.9-fold (0.77 log units) above the measured one; measured number below the stated range.
By their numbers in this assay, from the lowest: compound 4; then compounds 3, 1 and 2 (each within the scatter of the next).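

In this assay, 3-methylphenyl in place of 4-methylphenyl on a double-bonded ring carbon gives a 5.5-fold lower number from compound 3 to compound 4 (0.74 log units; beyond the scatter), so an isomer swap at this place can move the number beyond the scatter, which the chlorophenyl swap on the ring nitrogen did not do. With 3-methylphenyl held constant, bromo in place of chloro on an aromatic carbon gives a 9.3-fold lower number from compound 2 to compound 4 (0.97 log units; beyond the scatter), and 4-bromophenyl in place of 3-chlorophenyl gives a 7.7-fold lower number from compound 1 to compound 4 (0.89 log units; beyond the scatter), so compound 4 stands apart from all three earlier compounds. No measurement at hand accounts for these steps.

On these data alone, whether 3-methylphenyl gives a step of this size alongside a chlorophenyl on the ring nitrogen remains open. Also open, as far as these compounds go, is whether an amine or a carboxylic acid on that phenyl ring, or a longer chain in place of its methyl, would preserve the number of compound 4.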